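The compounds below may be only part of what the source reports. "The series", "measured", "known", "first", "only" and "open" are said of these compounds alone.

Of the compounds shown here, three have so far been read in an ADME assay on microsomes from liver (Mus musculus) for metabolic stability, read by LC-MS, using NADPH, tested at 1 uM; a lower number here means that the compound disappears faster, a higher number that the compound lasts longer. Compound 1 `Cc1nc2c(N)ncnc2n1[C@@H]1O[C@H](CN(C)C/C=C\CNC(=O)OCc2ccccc2)[C@@H](O)[C@H]1O` gives 0.217 h. Compound 2 `CCC(=O)NC/C=C\CN(C)C[C@H]1O[C@@H](n2cnc3c(N)ncnc32)[C@H](O)[C@@H]1O` is reported only as a limit, > 1.5 h, and not as a number. Compound 3 `CC(=O)NC/C=C\CN(C)C[C@H]1O[C@@H](n2cnc3c(N)ncnc32)[C@H](OC(C)=O)[C@@H]1OC(C)=O` gives 0.11 h, which lies within the usual scatter of the value for compound 1, so the two cannot be told apart. Going by the values given here, compound 3 therefore stands together with compound 1, and the only other reading is the limit.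

Compound 4 `CCCC(=O)NC/C=C\CN(C)C[C@H]1O[C@@H](n2cnc3c(N)ncnc32)[C@H](OC(C)=O)[C@@H]1OC(C)=O` has not yet been measured. It differs from compound 3 at a single place: ethyl in place of hydrogen on a saturated chain carbon bound to a carbonyl carbon, which turns acetamido into (propylcarbonyl)amino. Among the compounds with values here, no pair of measured compounds differs at one place only, so the data offer no direct guide to this change, and the expectation starts from compound 3 at 0.11 h. The expected step of no change at the digits printed from compound 3 to compound 4 (within the scatter) is none beyond the scatter in this assay, with neither direction favoured. For compound 4 the estimated half-life is 0.11 h, with an expected range of 0.05 h to 0.24 h.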

Compound 4, half-life: 0.05 h
The estimate for compound 4 lay 2.2-fold (0.34 log units) above the measured number; measured number inside the range.
By their numbers in this assay, from the lowest: compound 4; then compounds 3 and 1 (each within the scatter of the next). At a limit, above all of these: compound 2.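

In this assay, going by these compounds alone, ethyl in place of hydrogen on a saturated chain carbon bound to a carbonyl carbon, which turns acetamido into (propylcarbonyl)amino, gives a 2.2-fold lower number from compound 3 to compound 4 (0.34 log units; beyond the scatter), and this is the first change that can be read at a single place. It shows that the half-life responds to what stands at this place, and that lengthening the chain from acetyl to propylcarbonyl moves the number downwards on the structure that these two compounds share, although this single pair gives a direction for this one change and no trend with chain length. Nothing measured here offers a cause for the step.

Going by these compounds, it remains open whether a longer chain than propyl, a ring, an amine or a carboxylic acid at this place would lower the number further, leave it unchanged or raise it. On these data alone, it is also open whether the same change from acetamido to (propylcarbonyl)amino would give a step of similar size on a compound that carries free hydroxyl groups on the core in place of the acetyl esters.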